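Working notes: changing the benzyl group on sulfur

A few compounds are considered here, and "the series" means these few. Any claim that something is new, unique, unknown or untested is made for them only; others in the source may bear on it.

In a functional assay on DU-145 cells (Homo sapiens) for inhibition, read by trypan blue exclusion, with a stated time of 96 h (a higher number here means a weaker inhibitor of growth, a lower number a stronger inhibitor of growth), compound 1 `O=C(O)c1ccc(C(=O)/C(=C\c2ccc(Cl)c([N+](=O)[O-])c2)SCc2ccc(C(F)(F)F)cc2)cc1` gives 1000 nM and compound 2 `O=C(O)c1ccc(C(=O)/C(=C\c2ccc(Cl)c([N+](=O)[O-])c2)SCc2ccccc2F)cc1` gives 1000 nM, so compound 2 stands level with compound 1. Among the measured compounds shown here, the only measured step at this place is no change at the digits printed from compound 1 to compound 2 (within the scatter). Compound 3 `Cc1ccc(CS/C(=C/c2ccc(Cl)c([N+](=O)[O-])c2)C(=O)c2ccc(C(=O)O)cc2)cc1` differs from compound 2 as follows: 4-methylphenyl in place of 2-fluorophenyl on a saturated chain carbon bound to a sulfur. This puts 4-methylphenyl in place of 2-fluorophenyl on a saturated chain carbon bound to a sulfur. With that single step as the guide, no change beyond the scatter is expected in this assay. The expected step is no change at the digits printed from compound 2 to compound 3 (within the scatter). The estimate for compound 3 is 1000 nM, with an expected range of 400 nM to 2500 nM.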

Compound 3, concentration for 50% growth inhibition: 1000 nM
Estimate against measurement, compound 3: no gap at the digits printed; low and high end bracket the measured number.
By their numbers in this assay, from the lowest: compounds 1, 2 and 3 (each within the scatter of the next).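

At the saturated chain carbon bound to a sulfur, 4-methylphenyl in place of 2-fluorophenyl gives no change at the digits printed from compound 2 to compound 3 (within the scatter) in this assay, so a third benzyl group now reads level with the other two. Methyl in place of trifluoromethyl on an aromatic carbon gives no change at the digits printed from compound 1 to compound 3 (within the scatter) in the same read-out, the first step here that alters only one group on the ring. Nothing measured here explains this flat reading.

Still open, going by these compounds, is whether a benzyl group carrying an amine or a carboxylic acid would read differently. On these data alone, a longer chain in place of the benzyl group also remains open.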